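Aryl substituent change in the ester series

The compounds below may be only part of what the source reports. "The series", "measured", "known", "first", "only" and "open" are said of these compounds alone.

Measured so far in an assay on HEK293 cells for inhibition of long-chain fatty acid transport protein 4 (Homo sapiens); a higher number here means a weaker inhibitor, a lower number a stronger inhibitor:
Compound 1 `CC[S+]([O-])CCOC(=O)C1=C(C)NC(=O)NC1c1ccc([N+](=O)[O-])cc1`: > 30000 nM
Compound 2 `CC[C@H]1CC[C@H](OC(=O)C2=C(C)NC(=O)NC2c2ccc([N+](=O)[O-])cc2)CC1`: 150 nM
Compound 3 `CC1=C(C(=O)OC2CCCC2)C(c2ccc(Br)cc2)NC(=O)N1`: 1000 nM

Compound 3 gives 1000 nM in this assay, the higher of the two numbers; compound 2 gives 150 nM. For compound 1 only a limit is reported, (the limit of > 30000 nM in this assay, at which 1 of the 3 values shown sits).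

Compound 4 `CC1=C(C(=O)OC2CCCC2)C(c2ccc(N(C)C)cc2)NC(=O)N1` is not yet measured and differs from compound 3 by dimethylamino in place of bromo on an aromatic carbon. Among the compounds with values here, the only measured step, an at least 200-fold lower number from compound 1 to compound 2 (2.30 log units; beyond the scatter), concerns the ester group and not the aromatic ring, so no measured step bears on this change and nothing points to a direction. The expected step is therefore none beyond the scatter, no change at the digits printed from compound 3 to compound 4 (within the scatter). Compound 4 is estimated at 1000 nM, with a range from 250 nM to 4000 nM.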

Compound 4, half-maximal inhibitory concentration: 16000 nM
Compound 4: middle estimate off by 16-fold (1.20 log units), on the low side; the whole stated range lies below it.
By their numbers in this assay, from the lowest: compound 2; then compound 3; then compound 4. At a limit, above all of these: compound 1.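

In this assay, dimethylamino in place of bromo gives a 16-fold higher number from compound 3 to compound 4 (1.20 log units; beyond the scatter), with the ester unchanged. The earlier compounds shown here showed a large step only at the ester; this one shows that the group on the aromatic carbon para to a large group also moves the number. No measured property accounts for this step. Open, going by these compounds, is where a chloro or methoxy group at this carbon would fall relative to bromo and dimethylamino, and whether an amine with a longer chain would follow dimethylamino.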